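Terminal diethylamino on a longer alkoxy chain

The source may hold more compounds than are shown below. What is called first, only, known or untested is meant among the compounds shown, and "the series" means these compounds.

Compound 1 `CCCCCCOc1c(-c2cc(OC)c(OC)c(OC)c2)oc2ccccc2c1=O` is the reference point of the series. For the measured compounds named here, in a functional assay on LNCaP cells (Homo sapiens) for antiproliferative activity, read by WST assay, with a stated time of 3 days (a higher number here means a weaker inhibitor, a lower number a stronger inhibitor), compound 1 gives 19600 nM, the lowest of the two numbers so far. Compound 2 `CCN(CC)CCCOc1c(-c2cc(OC)c(OC)c(OC)c2)oc2ccccc2c1=O` places diethylamino three bonds along the chain from the oxygen on the aromatic ring; in this assay compound 2 gives 37600 nM, and the step of a 1.9-fold higher number from compound 1 to compound 2 (0.28 log units; within the scatter) stays within the scatter. Compound 3 `CCN(CC)CCCCCOc1c(-c2cc(OC)c(OC)c(OC)c2)oc2ccccc2c1=O` differs from compound 1 as follows: diethylamino in place of methyl on a saturated chain carbon, five bonds along the chain from an oxygen on an aromatic ring. Going by the values given here, the only measured step that bears on this change is a 1.9-fold higher number from compound 1 to compound 2 (0.28 log units; within the scatter), which introduced the same amine and moved the number only slightly. Among the compounds with values here, the chain length of compound 3 has no measured counterpart, so a step of similar size, at most a small rise, is expected for compound 3 in this assay: a 1.3-fold higher number from compound 1 to compound 3 (0.12 log units; within the scatter). Compound 3 is accordingly estimated at 26000 nM, with a range from 10000 nM to 65000 nM.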

Compound 3, half-maximal inhibitory concentration: 10000 nM
Beside the measured number, compound 3's estimate is 2.6-fold (0.41 log units) above it; the range from low to high includes it.
By their numbers in this assay, from the lowest: compounds 3, 1 and 2 (each within the scatter of the next, the first and the last beyond it).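

In this assay, diethylamino in place of methyl at this place, five bonds along the chain from an oxygen on an aromatic ring, does not separate compound 3 from compound 1 (a 2.0-fold lower number from compound 1 to compound 3 (0.29 log units; within the scatter)), so the terminal amine is tolerated at this chain length. For the compounds shown here, the clearer contrast lies between the two amines, where 2-(diethylamino)ethyl in place of diethylamino gives the only step here beyond the scatter, a modest one (a 3.8-fold lower number from compound 2 to compound 3 (0.58 log units; beyond the scatter)), showing that with the amine kept, its distance along the chain from the shared core can change the reading. No measurement shown here accounts for this difference.

From the compounds shown here alone, whether a longer chain ending in diethylamino would extend this step remains open, since two amine chain lengths define no trend. Also open, going by these compounds, is how a piperidine or a carboxylic acid at the chain end would compare.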